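Permeability of compound 4 after a small change in the chain

This account rests on a few compounds, and the source may have more. Where it says the series, first, only, none or still open, it means among the compounds named here.

Measured compounds:
- Compound 1, `O=C(NS(=O)(=O)c1ccccc1)c1ccc(Nc2nc(NC3(c4ccc(Cl)cc4)CC3)nc(OCC(F)(F)F)n2)cc1`: 182 nm/s
- Compound 2, `O=C(NS(=O)(=O)c1ccc(F)cc1)c1ccc(Nc2nc(NC3(c4ccc(Cl)cc4)CC3)nc(OCC(F)(F)F)n2)cc1`: 193 nm/s
- Compound 3, `O=C(NS(=O)(=O)CCNC(=O)C1CC1)c1ccc(Nc2nc(NC3(c4ccc(Cl)cc4)CC3)nc(OCC(F)(F)F)n2)cc1`: 1 nm/s

In a physicochemical assay for permeability, using PAMPA, at pH 7.4 (a lower number here means that the compound crosses the layer more slowly, a higher number that the compound crosses the layer faster), compound 3 gives the lowest of the three numbers, at 1 nm/s. The steps that reach it are both large: a 180-fold lower number from compound 1 to compound 3 (2.26 log units; beyond the scatter) and a 190-fold lower number from compound 2 to compound 3 (2.29 log units; beyond the scatter). By contrast the step of a 1.1-fold higher number from compound 1 to compound 2 (0.03 log units; within the scatter) is within the scatter.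

Compound 4, `COC(=O)NCCS(=O)(=O)NC(=O)c1ccc(Nc2nc(NC3(c4ccc(Cl)cc4)CC3)nc(OCC(F)(F)F)n2)cc1`, differs from compound 3 in one place: methoxy in place of cyclopropyl on a carbonyl carbon. Going by the values given here, none of the measured steps touches this place; the two large steps concern the group on the sulfonyl sulfur, which compound 4 shares with compound 3, and the small step concerns the aromatic ring that compound 4 does not carry. Among the compounds with values here, there is therefore no measured step that bears directly on this change, and the expectation for compound 4 in this assay is a step of no size beyond the scatter, no change at the digits printed from compound 3 to compound 4 (within the scatter). Compound 4 is estimated at 1 nm/s, with a range from 0.3 nm/s to 4 nm/s.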

Compound 4, apparent permeability: 39 nm/s
Compound 4: the middle estimate sits 39-fold (1.59 log units) below what was measured, outside the stated range (above it).
By their numbers in this assay, from the lowest: compound 3; then compound 4; then compounds 1 and 2 (each within the scatter of the next).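

In this assay, going by these compounds alone, the group on the carbonyl carbon proves to matter in its own right: methoxy in place of cyclopropyl gives a 39-fold higher number from compound 3 to compound 4 (1.59 log units; beyond the scatter), at a place that no earlier step touched. The low number of compound 3 is therefore not shared by every chain of this kind on the sulfonyl sulfur, as the 2-((methoxycarbonyl)amino)ethyl group gives only modest steps against the aromatic groups, a 4.9-fold lower number from compound 2 to compound 4 (0.69 log units; beyond the scatter) and a 4.7-fold lower number from compound 1 to compound 4 (0.67 log units; beyond the scatter). Nothing measured here accounts for the size of the change.

The compounds shown leave open whether the step follows the arrival of the methoxy oxygen or the loss of the cyclopropyl ring; an ethoxy or a methyl group on the same carbonyl carbon would speak to that. They also leave open whether a longer chain carrying the same (methoxycarbonyl)amino group behaves in the same way.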